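The compounds below may be only part of what the source reports. "The series", "measured", "known", "first", "only" and "open" are said of these compounds alone.

Compound 1 `COc1ccc(/C=C/C(=O)NCCCC(C)Nc2cc(OC)cc3cccnc23)cc1` and compound 2 `COc1cc(NC(C)CCCNC(=O)/C=C/c2ccc(OC)c(OC)c2)c2ncccc2c1` share a core and differ by a single methoxy group. In an ADME assay on L6 cells (Rattus norvegicus) for cytotoxicity, read by resazurin assay, with a stated time of 70 h (on this read-out higher numbers stand for weaker inhibition and lower numbers for stronger inhibition), compound 1 gives only a limit of the assay, > 100 ug/mL. Compound 2 likewise gives only a limit in this assay, > 100 ug/mL. With two limits and no number on either side, the step between them cannot be read: a step that the two limits leave unreadable from compound 1 to compound 2. Both values sit at the same ceiling, (the limit of > 100 ug/mL in this assay, at which 2 of the 2 values shown sit).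

Compound 3 `COc1cc(NC(C)CCCNC(=O)/C=C/c2cc(OC)c(OC)c(OC)c2)c2ncccc2c1` carries one more group than compound 2: methoxy in place of hydrogen on an aromatic carbon. Within the data shown here, the one measured step of the same kind gives no usable size, so no shift beyond the usual scatter is anticipated. Compound 2 stands at the limit, and compound 3 is estimated to land near it as well, at 150 ug/mL, within a range from 50 ug/mL to 500 ug/mL. The expected step amounts to a step that the limit leaves unreadable from compound 2 to compound 3.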

Compound 3, half-maximal inhibitory concentration: > 100 ug/mL
Compound 3 ended at the assay's limit; the forecaster's own chance of this, stated with the estimate: 70%; the middle value is on the limit's open side.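

No new step can be read from compound 2 to compound 3, because both results are limits of the assay rather than numbers: the limit of > 100 ug/mL in this assay, at which 3 of the 3 values shown sit.

The compounds shown leave open whether either added methoxy group changes the true value in this assay at all.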